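This account rests on a few compounds, and the source may have more. Where it says the series, first, only, none or still open, it means among the compounds named here.

Compound 2 `O=C(NCc1ccccc1)Nc1nc2ccc(NC(=O)c3c(Cl)cccc3Cl)cc2s1` stands with the higher of the two numbers recorded in a functional assay on WI-38 VA13 cells (Homo sapiens) for cytotoxicity; on this read-out lower numbers stand for an effect already at smaller amounts and higher numbers for an effect only at larger amounts of compound: compound 2 gives 0.15 ug/mL, whereas compound 1 `CC(C)COC(=O)Nc1nc2ccc(NC(=O)c3c(Cl)cccc3Cl)cc2s1` gives 0.0035 ug/mL. Going by the values given here, the only step between them, a 43-fold higher number from compound 1 to compound 2 (1.63 log units; beyond the scatter), was large. Compound 3 `COc1ccc(Nc2nc3ccc(NC(=O)c4c(Cl)cccc4Cl)cc3s2)cc1` differs from compound 2 by 4-methoxyphenyl in place of benzylcarbamoyl on a nitrogen on an aromatic ring. Among the compounds with values here, no measured step matches this change: the single known step exchanged one group on a carbonyl carbon, while here the whole benzylcarbamoyl group leaves and a 4-methoxyphenyl enters at that nitrogen. That step does show that altering this side of the shared core can shift the number by a large amount, so a sizeable move in either direction is possible and the direction stays uncertain. Compound 3 is therefore expected near 0.2 ug/mL, within 0.02 ug/mL to 2 ug/mL. The corresponding step, a 1.3-fold higher number from compound 2 to compound 3 (0.12 log units; within the scatter), is estimated to be modest against that wide range.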

Compound 3, half-maximal effective concentration: 0.87 ug/mL
Compound 3: the middle estimate sits 4.4-fold (0.64 log units) below what was measured; the range from low to high includes it.
By their numbers in this assay, from the lowest: compound 1; then compound 2; then compound 3.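

Putting 4-methoxyphenyl in place of benzylcarbamoyl on this nitrogen removes the carbonyl from the group there and still moves the number in this assay upward, with a 5.8-fold higher number from compound 2 to compound 3 (0.76 log units; beyond the scatter). The same 4-methoxyphenyl in place of isobutoxycarbonyl gives a 250-fold higher number from compound 1 to compound 3 (2.40 log units; beyond the scatter), so the three groups on this nitrogen now form an order, with isobutoxycarbonyl lowest, benzylcarbamoyl next and 4-methoxyphenyl highest, each gap beyond the scatter. No supporting information on why the numbers fall in this order is available.

The three compounds leave open whether the order goes with the carbonyl or with the rest of each group. A plain hydrogen, an acetyl group or an unsubstituted phenyl on this nitrogen would help to separate the two, as would a shorter or longer alkoxy chain on the carbonyl.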